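Chain extension on the glycerol phosphoserine-like series

This account rests on a few compounds, and the source may have more. Where it says the series, first, only, none or still open, it means among the compounds named here.

Measured so far:
compound 1 `CCCCCCCCCCCCCCCC(=O)OCCCOP(=O)(O)O[C@H](C)[C@H](N)C(=O)O` — 60 nM
compound 2 `CCCCCCCCCCCC(=O)OC[C@@H](O)COP(=O)(O)O[C@H](C)[C@H](N)C(=O)O` — 150 nM

In a functional assay on cells (Mast cell, Rattus norvegicus, strain Wistar) for activation, read by fluorescence, with a stated time of 15 min (on this read-out higher numbers stand for an effect only at larger amounts of compound and lower numbers for an effect already at smaller amounts), compound 2 gives the highest of the two numbers; compound 1 sits lower, and the gap lies beyond the usual scatter. Compound 3 `CCCCCCCCCCCCCCCC(=O)OC[C@@H](O)COP(=O)(O)O[C@H](C)[C@H](N)C(=O)O` differs from compound 2 by butyl in place of hydrogen on a saturated chain carbon, ten or more bonds along the chain from a carbonyl carbon, which brings its chain to the same length as in compound 1. Because compound 1 gives 60 nM, a step of a 1.9-fold lower number from compound 2 to compound 3 (0.27 log units; within the scatter) toward lower numbers is expected, though the two diols still differ. Compound 3 is therefore estimated at 80 nM, with a range from 35 nM to 180 nM.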

Compound 3, half-maximal effective concentration: 40 nM
The estimate for compound 3 lay 2.0-fold (0.30 log units) above the measured number, and the stated range covers the measured number.
By their numbers in this assay, from the lowest: compounds 3 and 1 (each within the scatter of the next); then compound 2.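

In this assay, butyl in place of hydrogen on a saturated chain carbon, ten or more bonds along the chain from a carbonyl carbon, gives a 3.8-fold lower number from compound 2 to compound 3 (0.57 log units; beyond the scatter) and so shows that chain length at this position matters beyond the scatter. Hydroxy in place of hydrogen on a saturated chain carbon bound to two saturated chain carbons gives a 1.5-fold lower number from compound 1 to compound 3 (0.18 log units; within the scatter) and is thus tolerated at this chain length. Nothing available explains either step.

As far as these compounds go, whether a chain longer than in compound 3 lowers the number further stays open, as does the effect of an amine in place of the hydroxy.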